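Removing the ring-amine protecting group in the pyrimidine amide series

This account rests on a few compounds, and the source may have more. Where it says the series, first, only, none or still open, it means among the compounds named here.

Three compounds built on the shared core of compound 1 `O=C(Nc1cc(Cl)cc2cccnc12)c1ncccn1` have numbers in a functional assay on MIA PaCa-2 cells (Homo sapiens) for inhibition, read by MTT assay, with a stated time of 72 h; on this read-out lower numbers stand for stronger inhibition and higher numbers for weaker inhibition. Compound 1 gives 800 nM in this assay. Compound 2 `Cc1cnc(C(=O)Nc2cc(OCCC3CCNCC3)cc3cccnc23)cn1` gives 6170 nM in this assay. Compound 3 `CC(C)(C)OC(=O)N1CCC(CCOc2cc(NC(=O)c3ncccn3)c3ncccc3c2)CC1` carries the protected ring amine and returns only a limit of the assay in this assay, > 10000 nM; it sits at the limit of > 10000 nM in this assay, at which 1 of the 3 values shown sits, the weakest end of what is shown. Compound 4 `O=C(Nc1cc(OCCC2CCNCC2)cc2cccnc12)c1ncccn1` differs from compound 3 by hydrogen in place of tert-butoxycarbonyl on an amine nitrogen in a ring. For the measured compounds named here, no step between measured compounds informs this change directly. Compound 2, which also carries the free ring amine on the same chain, gives 6170 nM in this assay, so the free amine is compatible with a measurable number. The step from compound 3 to compound 4 is therefore expected to run toward stronger inhibition, by about an at least 2.5-fold lower number from compound 3 to compound 4 (0.39 log units; beyond the scatter), though its size is uncertain given that compound 3 is only a limit. Compound 4 is estimated at 4000 nM, within 1000 nM to 15000 nM.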

Compound 4, half-maximal inhibitory concentration: > 10000 nM
Compound 4: no number, only a limit; the forecaster's own chance of this, stated with the estimate: 20%; middle value at least 2.5-fold (0.39 log units) away from the limit.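

In this assay compound 3 and compound 4 both stand at a limit of the assay, so hydrogen in place of tert-butoxycarbonyl brings no readable gain and the steps involving only these limits cannot be read: the limit of > 10000 nM in this assay, at which 2 of the 4 values shown sit. Placing 2-(piperidin-4-yl)ethoxy in place of chloro on the aromatic carbon gives an at least 12-fold higher number from compound 1 to compound 4 (1.09 log units; beyond the scatter), the one large change readable in this series. Pyrimidin-2-yl in place of 5-methylpyrazin-2-yl on the carbonyl carbon gives an at least 1.6-fold higher number from compound 2 to compound 4 (0.20 log units; that floor lies within the scatter), so this change cannot be separated from the usual scatter.

Going by these compounds, how far the free amine and its protected form differ stays open while both sit at a limit. Also open, on these data alone, is how a methoxy group in place of chloro, or an acetyl group on the ring amine nitrogen, would read in this assay on the shared core.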